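This account rests on a few compounds, and the source may have more. Where it says the series, first, only, none or still open, it means among the compounds named here.

Compound 3 `C#CCN(Cc1ccccc1)Cc1ccc2ccccc2c1` carries a propargyl group on an amine nitrogen. In an assay on HEK293 cells for binding affinity to Substance-K receptor (Rattus norvegicus), read by FRET, tested at 10 uM (on this read-out higher numbers stand for more inhibition at the one concentration tested (going by the name of the read-out) and lower numbers for less inhibition), compound 3 gives 0%. Compound 1 `N#CCN(C/C=C/c1ccccc1)Cc1ccccc1` gives 0% and compound 2 `N#CCN(Cc1ccccc1)Cc1ccc(C(F)(F)F)cc1` gives 0% in this assay, so the three values stand level within the usual scatter. Compound 4 `c1ccc(CN(Cc2ccc3ccccc3c2)c2ccncn2)cc1` has not yet been tested; it differs from compound 3 by pyrimidin-4-yl in place of propargyl on an amine nitrogen. For the measured compounds named here, no measured pair shows what such a change does in this assay. The step of a number 5 percentage points higher from compound 3 to compound 4 (within the scatter) is expected to show no change beyond the scatter, because in this assay compound 3 gives 0% and compounds 1 and 2 match it. Compound 4 is accordingly estimated at 5%, with a range from -10% to 25%.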

Compound 4, a percentage reported as inhibition, at one concentration (the size of the read-out at that concentration, not a potency): 34%
Estimate against measurement, compound 4: 29 percentage points below, outside the stated range (above it).
By their numbers in this assay, from the lowest: compounds 1, 2 and 3 (each within the scatter of the next); then compound 4.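

In this assay, for the compounds shown here, the group on this amine nitrogen clearly matters: pyrimidin-4-yl in place of propargyl gives a number 34 percentage points higher from compound 3 to compound 4 (beyond the scatter) and so lifts the reading beyond the scatter for the first time in this set. A short chain with a triple bond and no ring has given way to a six-membered aromatic ring with hetero atoms, and this single change is enough to move the number. Nothing at hand explains why this swap raises the inhibition.

Still open, going by these compounds, is whether the ring itself or its nitrogen atoms carry the step, a question that a phenyl or a pyridin-4-yl group at this place would address.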